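A few compounds are considered here, and "the series" means these few. Any claim that something is new, unique, unknown or untested is made for them only; others in the source may bear on it.

Four compounds share one core and differ only in the amide hanging from it. Compound 1 `CCOC(=O)c1sc(-c2cccc(NC(=O)c3ccc(C(F)(F)F)cc3)c2)nc1Nc1ccc(N2CCN(C)CC2)cc1` belongs to the set, and in a functional assay on Ramos cells (Homo sapiens) for antiproliferative activity, read by CCK-8 assay, with a stated time of 72 h (a lower number here means a stronger inhibitor, a higher number a weaker inhibitor), compound 1 gives "not determined" (no result reported). Compound 2 `CCOC(=O)c1sc(-c2cccc(NC(=O)c3ccc(F)cc3)c2)nc1Nc1ccc(N2CCN(C)CC2)cc1` belongs to the set as well, and in this assay compound 2 gives "not determined" (no result reported). For the measured compounds named here, compound 3 `CCOC(=O)c1sc(-c2cccc(NC(=O)c3ccccc3)c2)nc1Nc1ccc(N2CCN(C)CC2)cc1` carries a plain benzamide, and in this assay compound 3 gives 24800 nM, the only number available here, which marks it as a weak inhibitor. Compound 4 `CCOC(=O)c1sc(-c2cccc(NC(=O)c3ccccc3F)c2)nc1Nc1ccc(N2CCN(C)CC2)cc1` differs from it by fluoro in place of hydrogen on an aromatic carbon. Going by the values given here, no measured pair shows what such a change does, so a step within the usual scatter is expected, without a clear direction. The expected step is a 1.2-fold lower number from compound 3 to compound 4 (0.09 log units; within the scatter). Compound 4 is therefore estimated at 20000 nM, with a range from 8000 nM to 60000 nM.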

Compound 4, half-maximal inhibitory concentration: 2000 nM
Compound 4: middle estimate off by 10-fold (1.00 log units), on the high side; the whole stated range lies above it.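

In this assay, swapping one hydrogen for fluoro on an aromatic carbon ortho to a large group gives a 12-fold lower number from compound 3 to compound 4 (1.09 log units; beyond the scatter) and so lies beyond the usual scatter. This carbon of the benzamide ring is therefore sensitive, since adding a single heavy atom here changes the antiproliferative reading strongly. No measurement shown here accounts for this step. From the compounds shown here alone, how chloro, methyl or an amine at this same place would compare with fluoro stays open. Going by these compounds, it is also open whether fluoro on another carbon of this ring would give a similar step.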